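Changing One Side Group on a Shared Core

The source may hold more compounds than are shown below. What is called first, only, known or untested is meant among the compounds shown, and "the series" means these compounds.

In a functional assay (aorta) with Rattus norvegicus as the target (on this read-out higher numbers stand for an effect only at larger amounts of compound and lower numbers for an effect already at smaller amounts), compound 1 (`COc1ccc(-c2nc(N=C(N)N)sc2-c2ccc(OC)cc2)cc1`) gives 2 uM, compound 2 (`COc1ccc(-c2nc(/N=C(\N)N3CCOCC3)sc2-c2ccc(OC)cc2)cc1`) gives 66 uM and compound 3 (`COc1ccc(-c2nc(CNC(=O)NC(C)C)sc2-c2ccc(OC)cc2)cc1`) gives 5.7 uM. Compound 3 therefore holds the second highest of the three numbers, with a 2.9-fold higher number from compound 1 to compound 3 (0.45 log units; beyond the scatter) and a 12-fold lower number from compound 2 to compound 3 (1.06 log units; beyond the scatter).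

Compound 4 (`COc1ccc(-c2nc(C(=O)N=C(N)N)sc2-c2ccc(OC)cc2)cc1`) has not yet been measured. It differs from compound 3 in one group on an aromatic carbon: a group of 6 heavy atoms (2 carbon, 3 nitrogen, 1 oxygen; no ring) in place of a group of 8 heavy atoms (5 carbon, 2 nitrogen, 1 oxygen; no ring), on an aromatic carbon.

Swaps at this same carbon have already produced steps of different sizes. The large one, a 33-fold higher number from compound 1 to compound 2 (1.52 log units; beyond the scatter), brought in a group with a six-membered non-aromatic ring. The group entering compound 4 has no ring, like the groups of compound 1 and compound 3, and these two are separated only by the modest 2.9-fold higher number from compound 1 to compound 3 (0.45 log units; beyond the scatter).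

The estimate is a 1.1-fold lower number from compound 3 to compound 4 (0.06 log units; within the scatter), so no step beyond the usual scatter is expected in this assay. The expected value for compound 4 is 5 uM, with an estimated range from 1.5 uM to 25 uM.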

Compound 4, concentration for half-maximal effect: > 100 uM
Compound 4 gave a limit, no number (the forecaster's own chance of this, stated with the estimate: 5%); at least 20-fold (1.30 log units) between middle value and limit.
By their numbers in this assay, from the lowest: compound 1; then compound 3; then compound 2. At a limit, above all of these: compound 4.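

Compound 4 gives a limit, not a number: the limit of > 100 uM in this assay, at which 1 of the 4 values shown sits. Swaps at this carbon can now produce large steps without bringing in a ring, as an at least 50-fold higher number from compound 1 to compound 4 (1.69 log units; beyond the scatter) and an at least 17-fold higher number from compound 3 to compound 4 (1.24 log units; beyond the scatter) show, whereas the earlier pair of ringless groups, in compound 1 and compound 3, differed only modestly; the group in compound 4 carries a carbonyl that the group in compound 1 lacks. Compound 2, which has the ring, is not separated from compound 4 by what can be read, an at least 1.5-fold higher number from compound 2 to compound 4 (0.18 log units; that floor lies within the scatter).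

The compounds shown do not tell how far compound 4 lies past its limit, or why this group gives so large a step. Also open, from the compounds shown here alone, is where an amine, a carboxylic acid or a longer chain at this carbon would fall in this order.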